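Carboxyazetidine Replaces the Formyl Group on the Pendant Ring

The source may report more compounds than this note shows. Statements on the series, on what has been measured and on what is new or still open speak of the compounds shown alone.

Compound 1 `COc1ccc(/C=C\c2cc(OC)c(OC)c(OC)c2)cc1OCc1ccc(C=O)cc1` carries a formyl group on the ring attached through the benzyl ether of the shared core. Among the measured compounds shown here, in a functional assay on HepG2 cells (Homo sapiens) for antiproliferative activity, read by CCK-8 assay, with a stated time of 48 h (on this read-out lower numbers stand for stronger inhibition and higher numbers for weaker inhibition), compound 1 gives 800 nM, the lowest of the two numbers known; its nearest neighbour, compound 3 `COc1ccc(/C=C\c2cc(OC)c(OC)c(OC)c2)cc1OCc1ccc(CO)cc1`, gives 2400 nM in this assay, a step of a 3.0-fold higher number from compound 1 to compound 3 (0.48 log units; beyond the scatter) for hydroxymethyl in place of formyl. Compound 2 `COc1ccc(/C=C\c2cc(OC)c(OC)c(OC)c2)cc1OCc1ccc(CN[C@H](C(=O)O)[C@H](C)O)cc1` reaches only a limit of this assay, > 10000 nM, as one of the three values does (the limit of > 10000 nM in this assay, at which 1 of the 3 values shown sits). Compound 4 `COc1ccc(/C=C\c2cc(OC)c(OC)c(OC)c2)cc1OCc1ccc(CN2CC(C(=O)O)C2)cc1` is compound 1 with (3-carboxyazetidin-1-yl)methyl in place of formyl on an aromatic carbon. The most relevant measured step is the one in which ((1-carboxy-2-hydroxypropyl)amino)methyl replaced formyl, an at least 12-fold higher number from compound 1 to compound 2 (1.09 log units; beyond the scatter), since that change also introduces an aminomethyl bearing a carboxylic acid; even the smaller move to hydroxymethyl already weakened inhibition. Compound 4 is therefore expected to show a step of a 10-fold higher number from compound 1 to compound 4 (1.00 log units; beyond the scatter), a large move toward weaker inhibition, possibly to the limit. The estimate for compound 4 is 8000 nM, between 2500 nM and 30000 nM.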

Compound 4, half-maximal inhibitory concentration: > 10000 nM
Compound 4: a limit, no number; the forecaster's own chance of this, stated with the estimate: 40%; at least 1.2-fold (0.09 log units) between middle value and limit.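

In this assay compound 4 gives > 10000 nM, which is a limit of the assay and not a number. The move from formyl to (3-carboxyazetidin-1-yl)methyl gives an at least 12-fold higher number from compound 1 to compound 4 (1.09 log units; beyond the scatter), and the comparison with the hydroxymethyl compound gives an at least 4.1-fold higher number from compound 3 to compound 4 (0.61 log units; beyond the scatter), so at this position the large loss is not confined to the open chain of compound 2: a carboxylic acid held on a four-membered ring goes with it too. Compound 2 and compound 4 cannot be put in order, and the step between them cannot be read: the limit of > 10000 nM in this assay, at which 2 of the 4 values shown sit.

As far as these compounds go, what stays open is whether the amine or the carboxylic acid goes with the loss, as the two enter together in both compounds. A methyl ester in place of the acid, or an azetidin-1-ylmethyl group with no acid at all, would separate them.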